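The compounds below may be only part of what the source reports. "The series", "measured", "known", "first", "only" and "open" are said of these compounds alone.

Measured in a functional assay on U-937 cells (Homo sapiens) for antiproliferative activity, read by MTT assay; a higher number here means a weaker inhibitor, a lower number a stronger inhibitor:
compound 1 `COc1ccc2nc(N(Cc3cc(-c4cc(OC)c(OC)c(OC)c4)no3)c3nc4ccc(F)cc4s3)sc2c1`: 44000 nM
compound 2 `COc1ccc2nc(N(Cc3cc(-c4ccccc4F)no3)c3nc4ccc(F)cc4s3)sc2c1`: 29500 nM
compound 3 `FC(F)(F)Oc1ccc(-c2cc(CN(c3ncccn3)c3nc4ccccc4s3)on2)cc1`: 13500 nM

Compound 3 carries the lowest number of the three; compound 2 stands nearest to it, and the gaps from compound 2 and from compound 1 both lie beyond the scatter. Compound 4 `Fc1ccccc1-c1cc(CN(c2ncccn2)c2nc3ccccc3s2)on1` differs from compound 3 by 2-fluorophenyl in place of 4-(trifluoromethoxy)phenyl on an aromatic carbon. Going by the values given here, the only measured step that bears on this change is an aryl exchange at the same position on another core, a 1.5-fold lower number from compound 1 to compound 2 (0.17 log units; within the scatter), which stayed within the scatter. Among the compounds with values here, no measured step involves the trifluoromethoxyphenyl group itself. For compound 4 the expected step is therefore a 1.3-fold higher number from compound 3 to compound 4 (0.12 log units; within the scatter), small and, if anything, toward a higher number. In this assay compound 4 is estimated at 18000 nM, with a range from 7000 nM to 45000 nM.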

Compound 4, half-maximal inhibitory concentration: 27600 nM
The estimate for compound 4 lay 1.5-fold (0.19 log units) below the measured number; the measured number falls inside the stated range.
By their numbers in this assay, from the lowest: compound 3; then compounds 4, 2 and 1 (each within the scatter of the next).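

In this assay the aryl group on the aromatic carbon next to the ring nitrogen can move the number beyond the scatter: 2-fluorophenyl in place of 4-(trifluoromethoxy)phenyl gives a 2.0-fold higher number from compound 3 to compound 4 (0.31 log units; beyond the scatter) on the core of compound 3, whereas the exchange on the core of compound 1 gave a 1.5-fold lower number from compound 1 to compound 2 (0.17 log units; within the scatter) and stayed within the scatter. The entering group is the same in both steps, but the groups it replaces differ, so the two steps cannot be separated from their cores. Nothing shown explains the rise in the number with this change. The compounds shown leave open how an amine or a carboxylic acid on this phenyl ring would read, and whether 2-fluorophenyl and 4-(trifluoromethoxy)phenyl would keep this order on the core of compound 1.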